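The source may report more compounds than this note shows. Statements on the series, on what has been measured and on what is new or still open speak of the compounds shown alone.

The measured compounds, each with its result in a cytotoxicity test:

Compound 1 `Cc1cccc(/C(N)=N/NC(=S)N2CCSCC2)n1`: 1800 nM
Compound 2 `Cc1cccc(/C(N)=N/NC(=S)N2CCOCC2)n1`: 2200 nM
Compound 3 `N/C(=N\NC(=S)N1CCSCC1)c1ccc(F)cn1`: 1700 nM

In a functional assay on HeLa cells (Homo sapiens) for cytotoxicity, read by MTT assay, with a stated time of 72 h (on this read-out higher numbers stand for weaker inhibition and lower numbers for stronger inhibition), compound 1 gives 1800 nM and compound 2 gives 2200 nM. For the measured compounds named here, the only change between them is morpholin-4-yl in place of thiomorpholin-4-yl on a thiocarbonyl carbon, and it made a 1.2-fold higher number from compound 1 to compound 2 (0.09 log units; within the scatter). Compound 3 gives 1700 nM in this assay; the difference between its core and the core of compound 1 is not broken down here.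

Compound 4 `N/C(=N\NC(=S)N1CCOCC1)c1ccc(F)cn1` is not yet measured. It differs from compound 3 by morpholin-4-yl in place of thiomorpholin-4-yl on a thiocarbonyl carbon, the same change seen between compound 1 and compound 2, at the same kind of place. The expected step is a 1.2-fold higher number from compound 3 to compound 4 (0.07 log units; within the scatter), which rests on the earlier 1.2-fold higher number from compound 1 to compound 2 (0.09 log units; within the scatter) being within the scatter. Compound 4 is therefore estimated at 2000 nM, with a likely range from 1000 nM to 4000 nM.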

Compound 4, half-maximal inhibitory concentration: 1700 nM
Beside the measured number, compound 4's estimate is 1.2-fold (0.07 log units) above it, within the range that was stated.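

In this assay, putting morpholin-4-yl in place of thiomorpholin-4-yl on the thiocarbonyl carbon gives no change at the digits printed from compound 3 to compound 4 (within the scatter). Set beside the earlier step, the change carries from one core to the other with no difference that can be told from scatter: the same change on two cores in this assay, a 1.2-fold higher number (0.09 log units; within the scatter) from compound 1 to compound 2 and no change at the digits printed (within the scatter) from compound 3 to compound 4, 1.2-fold (0.09 log units) apart, within the scatter of two such steps. This shows that the swap makes no measurable difference on these two cores, but it does not show that either group is better, nor that the same would hold on any other core.

The compounds shown leave open what a different group on the thiocarbonyl carbon would do, such as an open-chain dimethylamino group or a piperazine ring with its free amine. They also leave open how the swap would behave on a core carrying a carboxylic acid.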